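Urea series: acetyl to carbamoyl on the aryl ring

This account rests on a few compounds, and the source may have more. Where it says the series, first, only, none or still open, it means among the compounds named here.

Compound 3 `CC(=O)c1ccc(NC(=O)Nc2ccc(F)c(C(F)(F)F)c2)cc1` gives 14 uL/min in an ADME assay on microsomes from liver (Mus musculus) for metabolic stability, using NADPH, with a stated time of 60 min (a lower number here means slower removal, a higher number faster removal of the compound), the lowest of the three numbers measured. Compound 2 `Cc1cc(NC(=O)Nc2ccc(F)c(C(F)(F)F)c2)on1` gives 108 uL/min and compound 1 `O=C(Nc1ccc(F)c(C(F)(F)F)c1)Nc1cnccn1` gives 160 uL/min; both stand beyond the scatter above compound 3. Among the compounds with values here, the only single-point step measured, a 1.5-fold lower number from compound 1 to compound 2 (0.17 log units; within the scatter), concerns the group on the amide-type nitrogen, not the carbonyl carbon changed here, and it lies within the scatter. Compound 4 `NC(=O)c1ccc(NC(=O)Nc2ccc(F)c(C(F)(F)F)c2)cc1` differs from compound 3 by amino in place of methyl on a carbonyl carbon. Within the data shown here, no measured step bears directly on this change, so no step beyond the scatter is expected in this assay. Compound 4 is estimated at 12 uL/min, with a range of 5 uL/min to 30 uL/min, meaning an expected step of a 1.2-fold lower number from compound 3 to compound 4 (0.07 log units; within the scatter).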

Compound 4, intrinsic clearance in a liver preparation (reported as CLH), per the amount of preparation that the assay uses in the Mus musculus assay: 22 uL/min
Compound 4: the middle estimate sits 1.8-fold (0.26 log units) below what was measured; the range from low to high includes it.
By their numbers in the Mus musculus assay, from the lowest: compounds 3 and 4 (each within the scatter of the next); then compounds 2 and 1 (each within the scatter of the next).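

the Mus musculus assay does not separate carbamoyl from acetyl at this position, with a 1.6-fold higher number from compound 3 to compound 4 (0.20 log units; within the scatter). In a physicochemical assay for solubility, read by nephelometry, measured as kinetic solubility, at pH 2 (on this read-out higher numbers stand for higher solubility and lower numbers for lower solubility), compound 3 gives < 1.6 ug/mL, which is a limit of the assay and not a number. In the physicochemical assay compound 4 gives 6.3 ug/mL, and an at least 3.9-fold higher number from compound 3 to compound 4 (0.59 log units; beyond the scatter) therefore has one end set by that limit: the limit of < 1.6 ug/mL in the physicochemical assay, at which 1 of the 2 values shown sits.

The compounds shown leave open whether a carboxylic acid or a methylamino group on this carbonyl carbon would keep the number in the Mus musculus assay near that of compound 4. They also leave open how either group would read in the physicochemical assay.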